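The source may report more compounds than this note shows. Statements on the series, on what has been measured and on what is new or still open speak of the compounds shown alone.

Compounds measured so far:
compound 1, `COc1cccc(Oc2c(NS(=O)(=O)c3ccc(C(C)(C)C)cc3)ncnc2OCCO)c1`, 160 nM
compound 2, `COc1cccc(Oc2c(NS(=O)(=O)c3ccc(C(C)(C)C)cc3)ncnc2OCCOc2ncc(C)cn2)c1`, 0.86 nM

Compound 1 `COc1cccc(Oc2c(NS(=O)(=O)c3ccc(C(C)(C)C)cc3)ncnc2OCCO)c1` and compound 2 `COc1cccc(Oc2c(NS(=O)(=O)c3ccc(C(C)(C)C)cc3)ncnc2OCCOc2ncc(C)cn2)c1` share one core and differ only at the end of the chain on the oxygen on a saturated carbon. In an assay on cells (Endothelial cell) for binding affinity to Endothelin-1 receptor (Sus scrofa) (a higher number here means a weaker inhibitor, a lower number a stronger inhibitor), compound 1 gives 160 nM, while compound 2 gives 0.86 nM. For the measured compounds named here, the single step between them, a 190-fold lower number from compound 1 to compound 2 (2.27 log units; beyond the scatter), shows that adding the 5-methylpyrimidin-2-yl group to that chain changes the number a great deal. Compound 2 therefore holds the lowest of the two numbers measured.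

Compound 3 `COc1cccc(Oc2c(NCCOc3ncccn3)ncnc2NS(=O)(=O)c2ccc(C(C)(C)C)cc2)c1` keeps the core and changes the chain: (2-((pyrimidin-2-yl)oxy)ethyl)amino in place of 2-((5-methylpyrimidin-2-yl)oxy)ethoxy on an aromatic carbon. The aromatic ring at the end of the chain stays, but its methyl is gone, and the chain is now attached through an amino group rather than an oxygen. Going by the values given here, no measured step covers either of these two changes; the only step known, from compound 1 to compound 2, concerns the whole tail, which compound 3 still carries. In this assay a modest step is therefore expected, most likely toward a somewhat higher number, as a 3.5-fold higher number from compound 2 to compound 3 (0.54 log units; beyond the scatter). Compound 3 is estimated at 3 nM, within 0.7 nM to 15 nM.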

Compound 3, half-maximal inhibitory concentration: 6.2 nM
Estimate against measurement, compound 3: 2.1-fold (0.32 log units) below; low and high end bracket the measured number.
By their numbers in this assay, from the lowest: compound 2; then compound 3; then compound 1.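

In this assay, a ring-ended chain on this aromatic carbon tolerates a change in how it is attached and in what the ring carries: with (2-((pyrimidin-2-yl)oxy)ethyl)amino in place of 2-((5-methylpyrimidin-2-yl)oxy)ethoxy, there is a 7.2-fold higher number from compound 2 to compound 3 (0.86 log units; beyond the scatter), a modest step that still lies beyond the scatter. Against the 2-hydroxyethoxy chain, the new chain gives a 26-fold lower number from compound 1 to compound 3 (1.41 log units; beyond the scatter), so a large drop in the number does not require both the chain oxygen attached to the aromatic carbon and the methyl on the end ring. Compound 3 nevertheless keeps only part of the gain seen with compound 2, and since the linking atom and the methyl changed together, the step cannot be divided between them.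

Nothing shown accounts for these shifts in the number. As far as these compounds go, it remains open how much of the step belongs to the amino link and how much to the lost methyl, and how the number would respond to a longer chain or to a phenyl ring in place of the pyrimidin-2-yl ring.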